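The source may hold more compounds than are shown below. What is called first, only, known or untested is meant among the compounds shown, and "the series" means these compounds.

In an assay on membranes from brain for displacement of a labelled ligand from adenosine receptor A1 (Rattus norvegicus), read by scintillation counting, with a stated time of 90 min (a lower number here means a stronger inhibitor, a higher number a weaker inhibitor), compound 1 `O=C(CCc1ccccc1)Nc1nc2ccccc2c(=O)s1` gives 422 nM, compound 2 `O=C(CCCc1ccccc1)Nc1nc2ccccc2c(=O)s1` gives 229 nM, and compound 3 `O=C(CCCc1cccc(Cl)c1)Nc1nc2ccccc2c(=O)s1` gives 898 nM. The highest number of the three belongs to compound 3: a 2.1-fold higher number from compound 1 to compound 3 (0.33 log units; beyond the scatter), and a 3.9-fold higher number from compound 2 to compound 3 (0.59 log units; beyond the scatter). Compound 4 `O=C(CCc1ccc(Cl)c(Cl)c1)Nc1nc2ccccc2c(=O)s1` differs from compound 3 by 3,4-dichlorophenyl in place of 3-chlorobenzyl on a saturated chain carbon, two bonds along the chain from a carbonyl carbon. Among the compounds with values here, two measured steps bear on this change. Shortening the chain runs opposite to a 1.8-fold lower number from compound 1 to compound 2 (0.27 log units; within the scatter), and adding a second chloro echoes a 3.9-fold higher number from compound 2 to compound 3 (0.59 log units; beyond the scatter). Both point the same way, so a small further rise in this assay, or no change beyond the scatter, is expected, and a 1.3-fold higher number from compound 3 to compound 4 (0.13 log units; within the scatter) is the step estimated. Compound 4 is therefore expected to give 1200 nM, with a likely range from 400 nM to 3600 nM.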

Compound 4, inhibition constant: > 1500 nM
Compound 4 was reported as a limit; the forecaster's own chance of this, stated with the estimate: 5%; middle value at least 1.2-fold (0.09 log units) away from the limit.
By their numbers in this assay, from the lowest: compounds 2 and 1 (each within the scatter of the next); then compound 3. At a limit, above all of these: compound 4.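

In this assay compound 4 is reported only as a limit: the limit of > 1500 nM in this assay, at which 1 of the 4 values shown sits. Replacing phenyl with 3,4-dichlorophenyl on the same chain gives an at least 3.5-fold higher number from compound 1 to compound 4 (0.55 log units; beyond the scatter), and replacing benzyl with it gives an at least 6.5-fold higher number from compound 2 to compound 4 (0.81 log units; beyond the scatter), so this group clearly weakens binding compared with either unsubstituted ring. Going by these compounds, the change from 3-chlorobenzyl is less settled, with an at least 1.6-fold higher number from compound 3 to compound 4 (0.22 log units; that floor lies within the scatter), so its true size remains unknown. The compounds shown leave open which of the two chloro groups matters more on the phenyl ring. They also leave open whether an amine or a carboxylic acid there would be tolerated.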